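Swapping the five-membered ring on a shared nucleoside core

The source may hold more compounds than are shown below. What is called first, only, known or untested is meant among the compounds shown, and "the series" means these compounds.

Compound 3 `OC[C@H]1OC(n2cnc3c(-c4ccoc4)ncnc32)[C@H](O)[C@@H]1O` carries a furan-3-yl group on its core. In a functional assay on CCRF-CEM cells (Homo sapiens) for inhibition (a higher number here means a weaker inhibitor, a lower number a stronger inhibitor), compound 3 gives 1650 nM, the highest of the two numbers recorded here. Its neighbour compound 1 `OC[C@H]1OC(n2cnc3c(-c4cc[nH]c4)ncnc32)[C@H](O)[C@@H]1O` has a 1H-pyrrol-3-yl group in the same spot, and in this assay compound 1 gives 1030 nM; the change a 1.6-fold higher number from compound 1 to compound 3 (0.20 log units; within the scatter) lies within the scatter. Compound 2 `Cn1nccc1-c1ncnc2c1ncn2C1O[C@H](CO)[C@@H](O)[C@H]1O` carries a methylated pyrazole in that position, and in this assay compound 2 gives "not active" (no number reported), with no number given.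

Compound 4 `Cc1ccsc1-c1ncnc2c1ncn2C1O[C@H](CO)[C@@H](O)[C@H]1O` is the next step: 3-methylthiophen-2-yl in place of furan-3-yl on an aromatic carbon. Within the data shown here, only the step from compound 1 to compound 3 bears on this kind of swap, and it was within the scatter, so a small change would be expected. Compound 2, however, shows that a ring carrying a methyl can lose activity altogether, so the range is kept wide. Compound 4 is estimated at 2500 nM, between 800 nM and 12000 nM, a step of a 1.5-fold higher number from compound 3 to compound 4 (0.18 log units; within the scatter) that is expected to be modest but uncertain.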

Compound 4, half-maximal inhibitory concentration: 2500 nM
The estimate for compound 4 equals the measured number at the digits printed, within the range that was stated.
By their numbers in this assay, from the lowest: compounds 1, 3 and 4 (each within the scatter of the next, the first and the last beyond it).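

A ring carrying a methyl group does not by itself abolish activity at this position: compound 4, with its 3-methylthiophen-2-yl group, still gives a number in this assay, whereas compound 2, with its methylated pyrazole, gives none. Among these compounds, the replacement of furan-3-yl stays within the scatter (a 1.5-fold higher number from compound 3 to compound 4 (0.18 log units; within the scatter)), but the comparison with 1H-pyrrol-3-yl gives the first step at this position that passes it, though only modestly (a 2.4-fold higher number from compound 1 to compound 4 (0.39 log units; beyond the scatter)). Nothing measured here explains either step.

On these data alone, compound 4 changes the ring atoms, the point of attachment and the methyl group all at once, so what each contributes remains open. So does the outcome with a group of another kind at this position, such as a phenyl ring or an amine.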